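Sulfone series: saturated ring in place of phenyl

The source may hold more compounds than are shown below. What is called first, only, known or untested is meant among the compounds shown, and "the series" means these compounds.

Compound 2 `O=C(Nc1ccc(S(=O)(=O)c2ccccc2)cc1)c1ccc([N+](=O)[O-])o1` gives 1100 nM in an assay on CHO-K1 cells for activation of DNA damage-inducible transcript 3 protein (Homo sapiens), read by a luciferase reporter; on this read-out higher numbers stand for an effect only at larger amounts of compound and lower numbers for an effect already at smaller amounts; compound 1 `CC1CN(S(=O)(=O)c2ccc(NC(=O)c3ccc([N+](=O)[O-])o3)cc2)CC(C)O1` gives 1400 nM, and the two stand within the scatter of each other, as a 1.3-fold lower number from compound 1 to compound 2 (0.10 log units; within the scatter) shows. Compound 3 `O=C(Nc1ccc(S(=O)(=O)C2CCOCC2)cc1)c1ccc([N+](=O)[O-])o1` carries the change (oxan-4-yl in place of phenyl on a sulfonyl sulfur). Among the compounds with values here, the single measured step on this position, the exchange of the 2,6-dimethylmorpholin-4-yl of compound 1 for phenyl, was within the scatter, so for compound 3 no step beyond the scatter is expected in this assay, that is a 1.1-fold higher number from compound 2 to compound 3 (0.04 log units; within the scatter). The estimate for compound 3 is 1200 nM, with a range from 500 nM to 3000 nM.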

Compound 3, concentration for half-maximal activity: 1200 nM
The estimate for compound 3 equals the measured number at the digits printed; the range from low to high includes it.
By their numbers in this assay, from the lowest: compounds 2, 3 and 1 (each within the scatter of the next).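

Oxan-4-yl, a non-aromatic ring with a hetero atom, is the first carbon-linked replacement for phenyl on the sulfonyl sulfur, and in this assay it gives a 1.1-fold higher number from compound 2 to compound 3 (0.04 log units; within the scatter) and a 1.2-fold lower number from compound 1 to compound 3 (0.07 log units; within the scatter) as its two steps. All three groups at this position therefore stand within the scatter of one another, so this read-out does not separate them. No supporting data speak to the reason for this result.

On these data alone, whether a small amine, a carboxylic acid or a longer alkyl chain on the sulfonyl sulfur would move the number beyond the scatter remains open.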